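This account rests on a few compounds, and the source may have more. Where it says the series, first, only, none or still open, it means among the compounds named here.

Compound 1 `C=C(Br)C(=O)Nc1cccc(-c2cn3nc(-c4ccc(F)cc4)sc3n2)c1` is one of two compounds tested in a functional assay on L1210 cells (Mus musculus) for inhibition, read by cell counting, with a stated time of 2 days (on this read-out lower numbers stand for stronger inhibition and higher numbers for weaker inhibition), where compound 1 gives 250 nM. That is the lower of the two numbers: the other compound, compound 2 `Nc1cccc(-c2cn3nc(Cc4ccccc4)sc3n2)c1`, gives 7400 nM in this assay, a gap well beyond the usual scatter. Compound 3 `C=C(Br)C(=O)Nc1cccc(-c2cn3nc(-c4ccc(C)cc4)sc3n2)c1` has not yet been measured. It differs from compound 1 in one spot: methyl in place of fluoro on an aromatic carbon. Going by the values given here, no measured pair shows this change, so only a small step is expected, a 1.4-fold higher number from compound 1 to compound 3 (0.15 log units; within the scatter), within the scatter or leaning toward a higher number. Compound 3 is therefore estimated at 350 nM, between 120 nM and 1000 nM.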

Compound 3, half-maximal inhibitory concentration: 920 nM
Beside the measured number, compound 3's estimate is 2.6-fold (0.42 log units) below it, and the stated range covers the measured number.
By their numbers in this assay, from the lowest: compound 1; then compound 3; then compound 2.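

In this assay, changing 4-fluorophenyl to 4-methylphenyl gives a 3.7-fold higher number from compound 1 to compound 3 (0.57 log units; beyond the scatter), so replacing one heavy atom on this ring, para to a large group, is enough to weaken inhibition beyond the usual scatter. Going by these compounds alone, this is the first step here that isolates this position, as compound 1 and compound 2 differ in more than one place. Nothing measured here explains why the methyl group gives the weaker inhibition.

As far as these compounds go, how an amine or a methoxy group at this position would compare remains open. So does whether hydrogen there would give a number closer to compound 1 or compound 3.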